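The source may hold more compounds than are shown below. What is called first, only, known or untested is meant among the compounds shown, and "the series" means these compounds.

In a functional assay on KB cells (Homo sapiens) for antiproliferative activity, read by colorimetric assay and MTT assay (a lower number here means a stronger inhibitor, a higher number a weaker inhibitor), compound 1 `COc1ccc(S(=O)(=O)Nc2cccc3cc(O)[nH]c23)cc1` gives 0.1 ug/mL and compound 2 `O=[N+]([O-])c1ccc(S(=O)(=O)Nc2cccc3cc(Cl)[nH]c23)cc1` gives 18 ug/mL. This is the higher of the two numbers, and its gap to compound 1 lies beyond the usual scatter. Compound 3 `O=[N+]([O-])c1ccc(S(=O)(=O)Nc2cccc3cc(O)[nH]c23)cc1` is still unmeasured and has hydroxy in place of chloro on an aromatic carbon relative to compound 2: hydroxy in place of chloro on an aromatic carbon. Among the measured compounds shown here, no measured pair isolates this change. Compound 1 carries the same hydroxy and gives 0.1 ug/mL, so a clear drop in the number, beyond the scatter, is expected. The expected size is an 18-fold lower number from compound 2 to compound 3 (1.26 log units; beyond the scatter). For compound 3 the estimated value is 1 ug/mL, with a range of 0.12 ug/mL to 9 ug/mL.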

Compound 3, half-maximal inhibitory concentration: > 100 ug/mL
Compound 3: no number, only a limit (the forecaster's own chance of this, stated with the estimate: 3%); middle value at least 100-fold (2.00 log units) from the limit.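

In this assay compound 3 gives a limit and not a number: the limit of > 100 ug/mL in this assay, at which 1 of the 3 values shown sits.

With the hydroxy kept, nitro in place of methoxy on an aromatic carbon gives an at least 1000-fold higher number from compound 1 to compound 3 (3.00 log units; beyond the scatter), so the hydroxy alone does not secure the low number of compound 1. With the nitro kept, hydroxy in place of chloro next to the ring nitrogen gives an at least 5.5-fold higher number from compound 2 to compound 3 (0.74 log units; beyond the scatter), so here the hydroxy goes with the weaker result.

Going by these compounds, both steps are lower bounds, so their full size stays open. Also open, on these data alone, is how an amine at this position would read alongside either nitro or methoxy.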